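A few compounds are considered here, and "the series" means these few. Any claim that something is new, unique, unknown or untested is made for them only; others in the source may bear on it.

The compounds measured in an ADME assay on NIH3T3 cells (Mus musculus) for cytotoxicity, read by MTT assay, with a stated time of 24 h; on this read-out higher numbers stand for weaker inhibition and lower numbers for stronger inhibition:
compound 1, `COc1ccc(-c2cs/c(=N/NC(=O)CSc3nnnn3-c3ccccc3)n2-c2ccccc2)cc1`, 11.7 ug/mL
compound 2, `O=C(CSc1nnnn1-c1ccccc1)N/N=c1/scc(-c2ccc(Cl)cc2)n1-c1ccccc1`, 313 ug/mL

Among the compounds with values here, compound 2 stands at the highest of the two numbers, that is, as the weaker inhibitor of the pair; the only step leading to it, a 27-fold higher number from compound 1 to compound 2 (1.43 log units; beyond the scatter), is large and beyond the scatter. Compound 3, `O=C(CSc1nnnn1-c1ccccc1)N/N=c1/scc(-c2ccccc2)n1-c1ccccc1`, has not yet been measured in this assay. It differs from compound 2 by hydrogen in place of chloro on an aromatic carbon. Within the data shown here, the one measured step, a swap of methoxy for chloro on the same aromatic carbon, is the only step that bears on this change; it shows the read-out to be highly sensitive to what sits there, but neither end of that step carries the unsubstituted phenyl of compound 3, so it gives a sense of size without a firm direction. A step in this assay that is probably beyond the scatter is therefore expected, more likely toward a lower number than a higher one, with wide uncertainty. Compound 3 is expected to give 100 ug/mL, in a range from 15 ug/mL to 400 ug/mL. The expected step is a 3.1-fold lower number from compound 2 to compound 3 (0.50 log units; beyond the scatter).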

Compound 3, half-maximal inhibitory concentration: 417 ug/mL
Beside the measured number, compound 3's estimate is 4.2-fold (0.62 log units) below it; the whole stated range lies below it.
By their numbers in this assay, from the lowest: compound 1; then compounds 2 and 3 (each within the scatter of the next).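

In this assay, replacing the 4-chlorophenyl with phenyl leaves the read-out within the scatter (a 1.3-fold higher number from compound 2 to compound 3 (0.12 log units; within the scatter)), so chloro and hydrogen on this aromatic carbon cannot be told apart, and the series now has the unsubstituted reference that the earlier pair lacked. Set against that reference, methoxy is the group that stands apart (a 36-fold higher number from compound 1 to compound 3 (1.55 log units; beyond the scatter)), and compound 1 is the strongest inhibitor of the three, so the large gap seen earlier goes with the presence of methoxy and not with that of chloro. No supporting data are available to explain why methoxy differs from the other two groups at this carbon.

Within the data shown here, with only three groups at this one position, it remains open whether the lower number is particular to methoxy or would also appear with hydroxy, ethoxy or an amine on the same carbon, and whether fluoro or methyl would read with chloro and hydrogen. Going by these compounds, it is also open whether the same swaps would behave alike on a core carrying a different group in place of the phenyl-tetrazole thioether part, or in any other assay.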